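Amine substituent on the shared core: butyl removed

A few compounds are considered here, and "the series" means these few. Any claim that something is new, unique, unknown or untested is made for them only; others in the source may bear on it.

Measured compounds:
- compound 1 `c1ccc(CNc2[nH]ccc3ncnc2-3)cc1` — in a functional assay (Homo sapiens) for inhibition of Nucleic Acid, tested at 100 uM (on this read-out higher numbers stand for more inhibition at the one concentration tested (going by the name of the read-out) and lower numbers for less inhibition), compound 1 gives 75%
- compound 2 `CCCCCCNc1[nH]ccc2ncnc1-2` — in this assay compound 2 gives 53%

Going by the values given here, compound 2 stands lowest of the two numbers measured so far; its nearest neighbour, compound 1, lies higher by a gap that exceeds the usual scatter. Among the compounds with values here, no pair differing in a single place has been measured, so no step size is known for this series.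

Compound 3 `CCNc1[nH]ccc2ncnc1-2` is not yet measured. It differs from compound 2 by hydrogen in place of butyl on a saturated chain carbon, two bonds along the chain from a nitrogen on an aromatic ring on the chain attached to the nitrogen.

Within the data shown here, with no measured step of this kind available, the direction is uncertain; a small decrease or no change beyond the scatter is expected. Compound 3 is estimated at 45%, within 20% to 70%. The expected step of a number 8 percentage points lower from compound 2 to compound 3 (within the scatter) is accordingly modest.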

Compound 3, a percentage reported as inhibition, at one concentration (the size of the read-out at that concentration, not a potency): 3%
Beside the measured number, compound 3's estimate is 42 percentage points above it; the whole stated range lies above it.
By their numbers in this assay, from the lowest: compound 3; then compound 2; then compound 1.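

In this assay, going by these compounds alone, hydrogen in place of butyl on a saturated chain carbon, two bonds along the chain from a nitrogen on an aromatic ring, gives a number 50 percentage points lower from compound 2 to compound 3 (beyond the scatter) as the first single-place step, and it is large. This position is therefore sensitive to how much chain it carries: with the shorter chain, compound 3 gives 3% in this assay and retains almost none of the inhibition seen at this one concentration. Nothing available accounts for the size of this step.

The compounds shown leave open how inhibition runs with chain length within this span, and whether the fall is gradual or abrupt; a propyl or butyl chain on the same nitrogen would bear on that. Also open, from the compounds shown here alone, is whether a longer chain such as octyl, or an amine or carboxylic acid at the chain end, keeps the inhibition.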